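Notes on the step from compound 3 to compound 4

The compounds below may be only part of what the source reports. "The series", "measured", "known", "first", "only" and "open" are said of these compounds alone.

Among the compounds with values here, in a functional assay on DU-145 cells (Homo sapiens) for inhibition, read by trypan blue exclusion, with a stated time of 72 h (a higher number here means a weaker inhibitor, a lower number a stronger inhibitor), compound 3 (`Cn1c(=O)c(S(=O)(=O)c2ccc(F)cc2F)cc2cnc(Nc3ccc4sccc4c3)nc21`) gives 500 nM, the lowest of the three numbers so far. Compound 1 (`O=c1c(S(=O)(=O)c2ccc(F)cc2F)cc2cnc(Nc3ccc4[nH]ccc4c3)nc2n1C1CCCC1`) gives 5000 nM and compound 2 (`Cn1c(=O)c(S(=O)(=O)Cc2ccc(F)cc2)cc2cnc(Nc3ccc4[nH]ccc4c3)nc21`) gives 30000 nM, both beyond the scatter from compound 3. Compound 4 (`Cn1ccc2cc(Nc3ncc4cc(S(=O)(=O)c5ccc(F)cc5F)c(=O)n(C)c4n3)ccc21`) has not yet been measured. It differs from compound 3 at one place, on a nitrogen on an aromatic ring, where 1-methyl-1H-indol-5-yl stands in place of 1-benzothiophen-5-yl: 1-methyl-1H-indol-5-yl in place of 1-benzothiophen-5-yl on a nitrogen on an aromatic ring. Within the data shown here, no measured pair differs in one place only, so this step has no direct precedent. Compound 1 at 5000 nM and compound 2 at 30000 nM lean the expectation only slightly towards a weaker number, since both also differ from compound 3 elsewhere. A modest weakening in this assay is expected, just beyond the scatter, with the estimated step being a 2.4-fold higher number from compound 3 to compound 4 (0.38 log units; beyond the scatter). For compound 4 the estimated value is 1200 nM, with an expected range of 300 nM to 5000 nM.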

Compound 4, half-maximal inhibitory concentration: 750 nM
Beside the measured number, compound 4's estimate is 1.6-fold (0.20 log units) above it; the measured number falls inside the stated range.
By their numbers in this assay, from the lowest: compounds 3 and 4 (each within the scatter of the next); then compound 1; then compound 2.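

Within the data shown here, this is the first pair that differs in one place only. In this assay the exchange on a nitrogen on an aromatic ring gives a 1.5-fold higher number from compound 3 to compound 4 (0.18 log units; within the scatter), so for this pair 1-methyl-1H-indol-5-yl and 1-benzothiophen-5-yl cannot be told apart, and the sulfur of the latter is not needed to keep the number at this level. Nothing measured on these compounds accounts for the two groups reading alike.

Open, going by these compounds, is how far this position tolerates other groups, for example a simple phenyl, or 1-methyl-1H-indol-5-yl carrying an amine or a carboxylic acid. Also open, on these data alone, is whether a longer chain in place of the methyl on the indole nitrogen keeps the number at this level.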